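The source may report more compounds than this note shows. Statements on the series, on what has been measured and on what is new or still open speak of the compounds shown alone.

Three compounds share one core, and one further compound remains to be measured in a functional assay on HeLa cells (Homo sapiens) for inhibition, read by MTT assay, with a stated time of 48 h; on this read-out lower numbers stand for stronger inhibition and higher numbers for weaker inhibition. Compound 1 `CCOC(=O)C1=C(N/C=N/c2nnc(S(N)(=O)=O)s2)Nc2[nH]nc(C)c2C1c1ccc(N(C)C)cc1` gives 26300 nM in this assay. Compound 2 `CCOC(=O)C1=C(N/C=N/c2cccnc2Cl)Nc2[nH]nc(C)c2C1c1ccc(N(C)C)cc1` gives 4630 nM in this assay. Compound 3 `CCOC(=O)C1=C(N/N=C(\c2ccc([N+](=O)[O-])cc2)N2CCN(c3ccc(F)cc3)CC2)Nc2[nH]nc(C)c2C1c1ccc(N(C)C)cc1` gives 87000 nM in this assay. On these numbers compound 2 stands lowest of the three, with compound 1 nearest and compound 3 furthest.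

Compound 4 `CCOC(=O)C1=C(N/C=N/c2ccc([N+](=O)[O-])cc2)Nc2[nH]nc(C)c2C1c1ccc(N(C)C)cc1` differs from compound 2 in one place: 4-nitrophenyl in place of 2-chloropyridin-3-yl on a double-bonded nitrogen. Among the compounds with values here, the only measured step touching that place is a 5.7-fold lower number from compound 1 to compound 2 (0.75 log units; beyond the scatter), where the group on the double-bonded nitrogen was exchanged, and that step reached beyond the scatter. Within the data shown here, compound 3 also carries a 4-nitrophenyl, but in a different setting, and no step links it to compound 2. Set beside the value of compound 2, compound 3 gives 87000 nM.

Among the measured compounds shown here, since the one relevant step shows that this position can shift the number by a modest amount, compound 4 is expected to move by a 1.9-fold higher number from compound 2 to compound 4 (0.29 log units; within the scatter), most likely a somewhat higher number than compound 2. Compound 4 is therefore estimated to give 9000 nM in this assay, within a range from 2500 nM to 30000 nM.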

Compound 4, half-maximal inhibitory concentration: 57800 nM
Beside the measured number, compound 4's estimate is 6.4-fold (0.81 log units) below it; the measured number lies above the stated range.
By their numbers in this assay, from the lowest: compound 2; then compound 1; then compounds 4 and 3 (each within the scatter of the next).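

In this assay, 4-nitrophenyl in place of 2-chloropyridin-3-yl gives a 12-fold higher number from compound 2 to compound 4 (1.10 log units; beyond the scatter) and so outweighs a 5.7-fold lower number from compound 1 to compound 2 (0.75 log units; beyond the scatter) as the largest step seen on the double-bonded nitrogen, which means this place can move the number further than the earlier pair showed. Set against the third group at this place, 4-nitrophenyl in place of 5-sulfamoyl-1,3,4-thiadiazol-2-yl gives a 2.2-fold higher number from compound 1 to compound 4 (0.34 log units; beyond the scatter) and places the three groups in a clear order, with 2-chloropyridin-3-yl lowest, 5-sulfamoyl-1,3,4-thiadiazol-2-yl next and 4-nitrophenyl highest, each gap lying beyond the scatter. No measurement at hand offers a reason for this order.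

The exchange between compound 2 and compound 4 alters the ring and its substituent together, so the compounds shown cannot tell how much of the step belongs to the ring nitrogen, how much to the chlorine and how much to the nitro group. An unsubstituted phenyl or a 2-chlorophenyl on the same nitrogen would bear on that question, and where either would fall among these three groups remains open.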